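This account rests on a few compounds, and the source may have more. Where it says the series, first, only, none or still open, it means among the compounds named here.

In a functional assay on GC-2 cells (Mus musculus) for cytotoxicity, read by MTT assay, with a stated time of 72 h (on this read-out higher numbers stand for weaker inhibition and lower numbers for stronger inhibition), compound 3 (`Nc1nc(Nc2ccc(S(N)(=O)=O)cc2)sc1C(=O)c1ccccc1[N+](=O)[O-]`) gives 9000 nM, the higher of the two exact numbers, and compound 1 (`Nc1nc(Nc2ccccc2)sc1C(=O)c1cccc(F)c1`) gives 4100 nM. Compound 2 (`Nc1nc(Nc2ccc(S(N)(=O)=O)cc2)sc1C(=O)c1cccnc1`) reaches only a limit of the assay, > 30000 nM. Compound 4 (`Nc1nc(Nc2ccc(S(N)(=O)=O)cc2)sc1C(=O)c1cccc(F)c1`) has 3-fluorophenyl in place of 2-nitrophenyl on a carbonyl carbon. Within the data shown here, the only measured step at that place is an at least 3.3-fold lower number from compound 2 to compound 3 (0.52 log units; beyond the scatter), a modest change that starts from a limit. Compound 1 also bears 3-fluorophenyl and shows 4100 nM, so no large loss is expected from this exchange. In this assay the expected change is small, a 1.3-fold lower number from compound 3 to compound 4 (0.11 log units; within the scatter), and no step beyond the scatter is anticipated. Compound 4 is estimated at 7000 nM, with an expected range from 2500 nM to 20000 nM.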

Compound 4, half-maximal inhibitory concentration: 3900 nM
Compound 4: middle estimate off by 1.8-fold (0.25 log units), on the high side, within the range that was stated.
By their numbers in this assay, from the lowest: compounds 4 and 1 (each within the scatter of the next); then compound 3. At a limit, above all of these: compound 2.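

Compound 4 shows that on this carbonyl carbon 3-fluorophenyl goes with a lower number than 2-nitrophenyl (a 2.3-fold lower number from compound 3 to compound 4 (0.36 log units; beyond the scatter)) and than pyridin-3-yl (an at least 7.6-fold lower number from compound 2 to compound 4 (0.88 log units; beyond the scatter)). In this assay, among these compounds, it also gives the first reading of sulfamoyl in place of hydrogen on an aromatic carbon, a step within the scatter (a 1.1-fold lower number from compound 1 to compound 4 (0.02 log units; within the scatter)). The step from compound 2 starts from a limit and not from a number: the limit of > 30000 nM in this assay, at which 1 of the 4 values shown sits.

Going by these compounds, how an unsubstituted phenyl or a 4-methoxyphenyl would read on this carbonyl carbon stays open. So does whether a carboxylic acid in place of sulfamoyl would leave the number as little moved.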